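The source may hold more compounds than are shown below. What is called first, only, known or untested is meant among the compounds shown, and "the series" means these compounds.

Compound 1 `O=C1NC(=O)/C(=C\c2ccc(OCC(=O)N3N=C(c4ccc(F)cc4)CC3c3ccccc3Cl)cc2)S1` gives > 50000 nM in an assay on cells for inhibition of histone deacetylase 8 (Homo sapiens), read by fluorescence, with a stated time of 30 min (a lower number here means a stronger inhibitor, a higher number a weaker inhibitor), a limit of the assay and not a number. Compound 2 `O=C1NC(=O)/C(=C\c2ccc(OCC(=O)N3N=C(c4ccc(F)cc4)CC3c3ccco3)cc2)S1` gives > 50000 nM in this assay, again a limit. Compound 3 `O=C1NC(=O)/C(=C\c2ccc(OCC(=O)N3N=C(c4ccc(F)cc4)CC3c3ccc(F)cc3)cc2)S1` gives > 50000 nM in this assay, also a limit.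

Compound 3 therefore stands at the limit where all three values sit (the limit of > 50000 nM in this assay, at which 3 of the 3 values shown sit). Compound 4 `O=C1NC(=O)/C(=C\c2ccc(OCC(=O)N3N=C(c4ccc(F)cc4)CC3c3ccc(Cl)c(Cl)c3)cc2)S1` differs from compound 3 in one place: 3,4-dichlorophenyl in place of 4-fluorophenyl on a saturated ring carbon. The steps at this position, a step that the two limits leave unreadable from compound 1 to compound 3 and a step that the two limits leave unreadable from compound 2 to compound 3, cannot be read in size, as both ends are limits, so no step beyond the scatter can be expected or excluded from them. Compound 4 is estimated to remain at the limit as well, with an expected step that the limit leaves unreadable from compound 3 to compound 4 and an estimated value of 80000 nM, within 30000 nM to 300000 nM.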

Compound 4, half-maximal inhibitory concentration: 25000 nM
For compound 4 the middle estimate is 3.2-fold (0.51 log units) above the measured one, outside the stated range (below it).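

In this assay, compound 4 is the only one of the compounds shown to give a readable number, so 3,4-dichlorophenyl is the one group here to leave the limit: the limit of > 50000 nM in this assay, at which 3 of the 4 values shown sit. The change gives an at least 2.0-fold lower number from compound 3 to compound 4 (0.30 log units; that floor lies within the scatter), an at least 2.0-fold lower number from compound 2 to compound 4 (0.30 log units; that floor lies within the scatter) and an at least 2.0-fold lower number from compound 1 to compound 4 (0.30 log units; that floor lies within the scatter). As far as these compounds go, each of these is only a floor, so the true size of the steps remains open, and the steps among compounds 1, 2 and 3 cannot be read.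

The compounds shown leave open whether 3-chlorophenyl or 4-chlorophenyl alone would also leave the limit. They also leave open how a 4-aminophenyl group would read at this position.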